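From 4-methoxyphenyl to 3,5-dimethoxyphenyl: notes on compound 4

The source may hold more compounds than are shown below. What is called first, only, known or untested is meant among the compounds shown, and "the series" means these compounds.

Measured so far in a functional assay on MV4-11 cells (Homo sapiens) for antiproliferative activity, read by luminescence and CellTiter-Glo, with a stated time of 72 h (a higher number here means a weaker inhibitor, a lower number a stronger inhibitor), as follows
- compound 1 `Cc1noc(C)c1-c1ccc2c(Nc3ccc(Cl)cc3)nn(C3CCCCO3)c2c1` gives 7400 nM
- compound 2 `Cc1ccc(Cn2nc(Nc3ccc(F)cc3)c3ccc(-c4c(C)noc4C)cc32)cc1` gives "not determined" (no result reported)
- compound 3 `CNc1cc(-c2ccc3cnn(Cc4ccc(OC)cc4)c3c2)cn(C)c1=O` gives 2700 nM

For the measured compounds named here, compound 2 has no number, so only two values can be compared. Of these, compound 3 at 2700 nM holds the lower, and compound 1 at 7400 nM lies higher by more than the usual scatter. The two structures differ in more than one place, and that gap says nothing about any single change.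

Next in line is compound 4 `CNc1cc(-c2ccc3cnn(Cc4cc(OC)cc(OC)c4)c3c2)cn(C)c1=O`, which keeps the core of compound 3. The change is 3,5-dimethoxyphenyl in place of 4-methoxyphenyl on a saturated chain carbon bound to an aromatic nitrogen with 3,5-dimethoxyphenyl in place of 4-methoxyphenyl on a saturated chain carbon bound to an aromatic nitrogen.

Going by the values given here, no measured pair isolates this kind of change, so the only anchor in this assay is compound 3 at 2700 nM and the expectation stays loose. A small move toward a lower number is expected, with a 1.5-fold lower number from compound 3 to compound 4 (0.18 log units; within the scatter) as the estimated step, not clearly beyond the scatter. For compound 4 the estimated value is 1800 nM with an expected range from 500 nM to 6000 nM in this assay.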

Compound 4, half-maximal inhibitory concentration: 190 nM
Estimate against measurement, compound 4: 9.5-fold (0.98 log units) above; the measured number lies below the stated range.
By their numbers in this assay, from the lowest: compound 4; then compound 3; then compound 1.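

In this assay, for the compounds shown here, the replacement of 4-methoxyphenyl by 3,5-dimethoxyphenyl gives a 14-fold lower number from compound 3 to compound 4 (1.15 log units; beyond the scatter) and is the first single change that can be read on its own. The earlier compounds offered only a gap between structures differing in more than one place, whereas here the rest of the structure is held constant, so the group on a saturated chain carbon bound to an aromatic nitrogen is shown to have a strong bearing on the antiproliferative read-out. Nothing available accounts for the size of this step, and no cause can be assigned to it.

Going by these compounds alone, the single step swaps one substituted phenyl for another, so it does not separate the loss of the 4-methoxy arrangement from the gain of the 3,5-dimethoxy arrangement, and it cannot show whether both methoxy groups of compound 4 are needed. The compounds shown also leave open how unsubstituted phenyl, or a hydroxyl, an amine or a longer alkoxy chain in place of the methoxy groups, would behave at this position.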